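Lengthening the Link to the Cyclohexyl Ring

The source may report more compounds than this note shows. Statements on the series, on what has been measured and on what is new or still open speak of the compounds shown alone.

Compound 1 `O=C(O)c1ccccc1-c1ccc(CCc2ncc(CC3CCCCC3)[nH]2)cc1` is the reference point here. For the measured compounds named here, in an in vitro functional assay on cells for agonist activity at Bombesin receptor subtype-3 (Homo sapiens), read by luminescence and calcium flux (on this read-out higher numbers stand for an effect only at larger amounts of compound and lower numbers for an effect already at smaller amounts), compound 1 gives 41 nM, the lowest of the three numbers so far. Compound 2 `N#Cc1ccc(Cc2cnc(CCc3ccc(-c4ccccc4C(=O)O)cc3)[nH]2)cc1` gives 5890 nM, and compound 3 `O=C(O)c1ccccc1-c1ccc(CCc2ncc(Cc3cccc(F)c3)[nH]2)cc1` gives 159 nM. The step of a 140-fold higher number from compound 1 to compound 2 (2.16 log units; beyond the scatter) and the step of a 3.9-fold higher number from compound 1 to compound 3 (0.59 log units; beyond the scatter) both show that exchanging the cyclohexyl on the saturated chain carbon for a flat ring costs potency, and a 37-fold lower number from compound 2 to compound 3 (1.57 log units; beyond the scatter) shows that the two flat rings themselves differ greatly.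

Compound 4 `O=C(O)c1ccccc1-c1ccc(CCc2ncc(CCC3CCCCC3)[nH]2)cc1` is the next compound in this series. Its change from compound 1 is cyclohexylmethyl in place of cyclohexyl on a saturated chain carbon bound to an aromatic carbon. The ring stays the same; only the link to it grows by one carbon. Going by the values given here, none of the measured steps tests such a lengthening, since all of them swap the ring itself rather than the chain, so there is no direct guide. Because compound 1 at 41 nM already has the saturated ring that the measured steps favour, the expectation is that compound 4 stays in the same region, with a change of roughly a 2.0-fold higher number from compound 1 to compound 4 (0.29 log units; within the scatter) expected in this assay, possibly within the scatter. The estimate for compound 4 is 80 nM, with a range from 20 nM to 400 nM.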

Compound 4, half-maximal effective concentration: 642 nM
For compound 4 the middle estimate is 8.0-fold (0.90 log units) below the measured one; the measured number lies above the stated range.
By their numbers in this assay, from the lowest: compound 1; then compound 3; then compound 4; then compound 2.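

Keeping the saturated ring does not by itself keep the number low at this position. With cyclohexylmethyl in place of cyclohexyl, the ring type is unchanged, yet this assay shows a 16-fold higher number from compound 1 to compound 4 (1.19 log units; beyond the scatter), so the length of the link matters here as well as the identity of the ring. The lengthened chain also changes how the saturated and flat rings rank: the data show a 4.0-fold higher number from compound 3 to compound 4 (0.61 log units; beyond the scatter), which puts compound 4 behind a flat-ring compound, but also a 9.2-fold lower number from compound 2 to compound 4 (0.96 log units; beyond the scatter), which leaves it ahead of the other flat-ring compound, and nothing available explains why the link has this effect.

The compounds shown leave open how the number responds on the other side of compound 1, with a cyclohexyl ring bound straight to the core, and whether a longer chain would raise it further. They also leave open whether a tetrahydropyranyl ring or a cyclopentyl ring at the end of the link would behave as the cyclohexyl ring does.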